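Piperazine substituent growth on a shared core: from ethyl to neopentyl

This account rests on a few compounds, and the source may have more. Where it says the series, first, only, none or still open, it means among the compounds named here.

Measured so far:
compound 1, `Cc1nc(N2CCC(N3CCCC3)CC2)nc2ccc(NC(=O)C(C)Oc3ccc(Cl)cc3)cc12`, 401 nM in a functional assay on CHO-K1 cells for antagonist activity at melanin-concentrating hormone receptor 1 (Homo sapiens), read by inositol phosphate accumulation; on this read-out lower numbers stand for stronger inhibition and higher numbers for weaker inhibition
compound 2, `CCC1(O)CCN(c2nc(C)c3cc(NC(=O)COc4ccc(OC(F)(F)F)cc4)ccc3n2)CC1`, 59 nM in this assay
compound 3, `CCN1CCN(c2nc(C)c3cc(NC(=O)COc4ccc(Cl)cc4)ccc3n2)CC1`, "not determined" (no result reported) in this assay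

Compound 1 and compound 2 differ from each other in several places at once, so their two values can only be placed side by side: compound 2 gives the lower number in this assay and compound 1 the higher one. Compound 3 stands on no number at all; it was not determined, so nothing about its own activity can be read from it. Compound 4, `Cc1nc(N2CCN(CC(C)(C)C)CC2)nc2ccc(NC(=O)COc3ccc(Cl)cc3)cc12`, has not yet been measured in this assay.

The change from compound 3 to compound 4 is:

tert-butyl in place of methyl on a saturated chain carbon bound to an amine nitrogen in a ring

For the measured compounds named here, no measured pair shows what this change does here, so the size of the step is open; the expectation is modest, within or only a little beyond the scatter, in either direction.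

Compound 4 is estimated to give 150 nM in this assay, expected to lie between 40 nM and 600 nM.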

Compound 4, half-maximal inhibitory concentration: 246 nM
Compound 4: the middle estimate sits 1.6-fold (0.21 log units) below what was measured, within the range that was stated.
By their numbers in this assay, from the lowest: compound 2; then compounds 4 and 1 (each within the scatter of the next).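

In this assay compound 4 gives 246 nM but compound 3 has no value to set against it, so no step can be read between them. Going by these compounds, what going from ethyl to neopentyl does to activity stays open, and no evidence bears on this result.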